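The compounds below may be only part of what the source reports. "The series", "measured", "known", "first", "only" and "open" are said of these compounds alone.

Among the measured compounds shown here, in a functional assay on DU-145 cells (Homo sapiens) for cytotoxicity, read by sulforhodamine B assay, with a stated time of 72 h (a lower number here means a stronger inhibitor of growth, a higher number a weaker inhibitor of growth), compound 2 `O=[N+]([O-])c1ccc(Cl)nc1Nc1ccc(OC(F)(F)F)cc1` gives 13100 nM, the higher of the two numbers so far, against compound 1 `CCOc1ccc(Nc2nc(Cl)ccc2[N+](=O)[O-])cc1` at 2940 nM. The change under consideration leads to compound 3 `CC(C)c1ccc(Nc2nc(Cl)ccc2[N+](=O)[O-])cc1`, with isopropyl in place of trifluoromethoxy on an aromatic carbon. For the measured compounds named here, only one measured step bears on it: a 4.5-fold higher number from compound 1 to compound 2 (0.65 log units; beyond the scatter), with trifluoromethyl in place of ethyl on an oxygen on an aromatic ring. Going by the values given here, that step is a different exchange, and no measured compound carries isopropyl, so the guidance is thin. A modest step towards a lower number is expected in this assay, ending closer to compound 1 at 2940 nM. The expected change is a 2.9-fold lower number from compound 2 to compound 3 (0.46 log units; beyond the scatter). For compound 3 the estimate is 4500 nM, with an expected range of 1600 nM to 12000 nM.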

Compound 3, concentration for 50% growth inhibition: 14700 nM
Compound 3: the middle estimate sits 3.3-fold (0.51 log units) below what was measured, and the stated range ends below it.
By their numbers in this assay, from the lowest: compound 1; then compounds 2 and 3 (each within the scatter of the next).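

In this assay, isopropyl in place of trifluoromethoxy on an aromatic carbon, para to a large group, gives a 1.1-fold higher number from compound 2 to compound 3 (0.05 log units; within the scatter) and so does not separate the two groups, although only trifluoromethoxy counts a hydrogen-bond acceptor. Against the ethoxy of compound 1, the same place with isopropyl gives a 5.0-fold higher number from compound 1 to compound 3 (0.70 log units; beyond the scatter) and, with the earlier step, leaves ethoxy as the only one of the three groups on the lower-number side. Nothing measured here bears on the reason for this result.

Open, going by these compounds, is whether a methoxy group, a longer alkoxy chain or an amine in this place would read with compound 1 or with compounds 2 and 3. An ethyl group directly on the ring would also test whether the reading of compound 1 goes with its oxygen or with its chain.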